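Swapping an oxy link for sulfanyl in MCF7 cytotoxicity

The source may hold more compounds than are shown below. What is called first, only, known or untested is meant among the compounds shown, and "the series" means these compounds.

Compound 1, `Cc1cc(C)nc(Oc2ccc(NC(=O)Nc3ccccc3)cc2)n1`: "not determined" (no result reported)
Compound 2, `Cc1cc(C)nc(Oc2ccc(NC(=O)Nc3ccc(OC(F)(F)F)cc3)cc2)n1`: > 50000 nM
Compound 3, `Cc1cc(C)nc(Oc2ccc(NC(=O)Nc3ccc(Cl)cc3)cc2)n1`: > 50000 nM

In a functional assay on MCF7 cells (Homo sapiens) for cytotoxicity, read by MTT assay, with a stated time of 3 days (on this read-out higher numbers stand for weaker inhibition and lower numbers for stronger inhibition), compound 2 sits at a limit of the assay, > 50000 nM, not at a number. Compound 3 also sits at a limit, > 50000 nM. For compound 1 no result is reported. Compound 4, `Cc1cc(C)nc(Sc2ccc(NC(=O)Nc3ccc(OC(F)(F)F)cc3)cc2)n1`, differs from compound 2 in one place: (4,6-dimethylpyrimidin-2-yl)sulfanyl in place of (4,6-dimethylpyrimidin-2-yl)oxy on an aromatic carbon. Among the compounds with values here, the only measured step, a step that the two limits leave unreadable from compound 2 to compound 3, cannot be read, as the limit of > 50000 nM in this assay, at which 2 of the 3 values shown sit, shows, so no measured step speaks to the change from compound 2 to compound 4. Compound 4 is therefore expected to remain near the same limit, with an expected step that the limit leaves unreadable from compound 2 to compound 4. The estimate for compound 4 is 70000 nM, ranging from 20000 nM to 300000 nM.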

Compound 4, half-maximal inhibitory concentration: 41700 nM
Estimate against measurement, compound 4: 1.7-fold (0.22 log units) above; measured number inside the range.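

In this assay, within the data shown here, (4,6-dimethylpyrimidin-2-yl)sulfanyl in place of (4,6-dimethylpyrimidin-2-yl)oxy gives the first reading that is a number and not a limit, with an at least 1.1-fold lower number from compound 2 to compound 4 (0.07 log units; that floor lies within the scatter). That step is only a floor and establishes no real change, and the earlier step between the two compounds at the limit cannot be read. Its true size stays unknown because the starting value is itself a limit: the limit of > 50000 nM in this assay, at which 2 of the 4 values shown sit.

From the compounds shown here alone, it remains open whether an amine link at this position would read differently. Going by these compounds, it is also open whether the same sulfanyl change would give a number when made on compound 3.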